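Methoxyphenyl Replaces Methoxybenzyl on the Second Core

The source may report more compounds than this note shows. Statements on the series, on what has been measured and on what is new or still open speak of the compounds shown alone.

Compound 3 `C=C(Br)C(=O)Nc1cccc(-c2cn3nc(Cc4cccc(OC)c4)sc3n2)c1` gives 3100 nM in a functional assay on CCRF-CEM cells (Homo sapiens) for inhibition, read by cell counting, with a stated time of 3 days (a higher number here means a weaker inhibitor, a lower number a stronger inhibitor), the highest of the three numbers shown. Compound 2 `C=C(Br)C(=O)Nc1cccc(-c2cn3c(-c4ccccc4)csc3n2)c1` gives 2800 nM, within the scatter of compound 3, while compound 1 `C=C(Br)C(=O)Nc1cccc(-c2cn3c(-c4ccc(OC)cc4)csc3n2)c1` gives 500 nM, beyond the scatter from both. Within the data shown here, the only single-point step measured, a 5.6-fold higher number from compound 1 to compound 2 (0.75 log units; beyond the scatter), shows how much a methoxy change can move this assay. Compound 4 `C=C(Br)C(=O)Nc1cccc(-c2cn3nc(-c4ccc(OC)cc4)sc3n2)c1` differs from compound 3 by 4-methoxyphenyl in place of 3-methoxybenzyl on an aromatic carbon. Among the measured compounds shown here, no measured step covers this exact change, and compound 1 shares the 4-methoxyphenyl group but not the core of compound 3, so the comparison is indirect. A step toward stronger inhibition is expected, a 3.9-fold lower number from compound 3 to compound 4 (0.59 log units; beyond the scatter). Because compound 1 gives 500 nM, compound 4 is estimated at 800 nM, with a range from 250 nM to 2500 nM.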

Compound 4, half-maximal inhibitory concentration: 1200 nM
Estimate against measurement, compound 4: 1.5-fold (0.18 log units) below; the measured number falls inside the stated range.
By their numbers in this assay, from the lowest: compound 1; then compound 4; then compounds 2 and 3 (each within the scatter of the next).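

On the shared core, the aromatic carbon next to the ring sulfur responds to the group it carries: in this assay there is a 2.6-fold lower number from compound 3 to compound 4 (0.41 log units; beyond the scatter). Among these compounds, earlier compounds showed a methoxy change only on another core, so this is the first step at this position. The data shown offer no explanation for this step.

The step combines removal of the benzyl carbon with a different methoxy placement, and the compounds shown do not separate the two. Also open, going by these compounds, is how an amine or a carboxylic acid in place of the methoxy would read here.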